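A Third Methyl on the Ring of Compound 3

The source may hold more compounds than are shown below. What is called first, only, known or untested is meant among the compounds shown, and "the series" means these compounds.

Measured in an assay on isolated protein for binding affinity to Melanocortin receptor 4 (Homo sapiens); a lower number here means a stronger inhibitor, a higher number a weaker inhibitor:
Compound 1, `CCCn1ccnc1-c1cccc(Cl)c1CCc1cc(Br)ccc1OC`, gives 1300 nM.
Compound 2, `CCC(C)n1ccnc1-c1cccc(Cl)c1CCc1cc(Br)ccc1OC`, gives 2500 nM.
Compound 3, `COc1ccc(Br)cc1CCc1ccccc1-c1ncc(C)n1C`, gives 180 nM.

Compound 3 holds the lowest number of the three in this assay; both compound 1 and compound 2 sit above it by more than the scatter, so it is the strongest binder of the set as measured. Compound 4, `COc1ccc(Br)cc1CCc1ccccc1-c1nc(C)c(C)n1C`, is derived from compound 3 by one change: methyl in place of hydrogen on an aromatic carbon. Going by the values given here, the only measured step in the set is a 1.9-fold higher number from compound 1 to compound 2 (0.28 log units; within the scatter), which concerns a methyl on a saturated chain carbon rather than on an aromatic ring carbon, so it bears on the new step only loosely; it shows that one added methyl can leave the number essentially where it was. Among the compounds with values here, no measured pair in the set adds a methyl on the five-membered aromatic ring, so there is no direct precedent. The expectation is therefore a step of no clear size in this assay, a 1.1-fold higher number from compound 3 to compound 4 (0.05 log units; within the scatter), with a wide allowance either way. Compound 4 is estimated at 200 nM in this assay, within a range from 60 nM to 700 nM.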

Compound 4, inhibition constant: 140 nM
Beside the measured number, compound 4's estimate is 1.4-fold (0.15 log units) above it; the range from low to high includes it.
By their numbers in this assay, from the lowest: compounds 4 and 3 (each within the scatter of the next); then compounds 1 and 2 (each within the scatter of the next).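

In this assay, the change from 1,5-dimethyl-1H-imidazol-2-yl to 1,4,5-trimethyl-1H-imidazol-2-yl gives a 1.3-fold lower number from compound 3 to compound 4 (0.11 log units; within the scatter), so compound 3 and compound 4 cannot be told apart in this assay. The earlier compounds shown here showed the effect of an added methyl only on a saturated chain carbon, whereas this result shows that an aromatic carbon of the five-membered ring, next to the ring nitrogen and next to the ring atom that bears a methyl group, can also carry a methyl while the number stays within the scatter. Nothing available here explains why the number holds at this position.

The compounds shown leave open whether this ring carbon would accept anything other than a methyl, such as an ethyl group, an amine or a carboxylic acid, since a single small group says little about the limits of the position. They also leave open whether the same methyl would leave the number in place on the core of compound 1, which carries a chlorine and a propyl group in place of the hydrogen and methyl of compound 3.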